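The source may hold more compounds than are shown below. What is called first, only, known or untested is meant among the compounds shown, and "the series" means these compounds.

Compound 1 `O=C1/C(=C/c2ccccc2)Cc2cc(O)ccc21` gives 376 nM in an assay on isolated protein for inhibition of Amine oxidase [flavin-containing] B (Homo sapiens), read by fluorescence and spectrophotometry, with a stated time of 20 min; on this read-out higher numbers stand for weaker inhibition and lower numbers for stronger inhibition. Compound 2 `CN(C)c1ccc(/C=C2\Cc3cc(O)ccc3C2=O)cc1` gives 768 nM in this assay and so has the higher of the two numbers shown, after a 2.0-fold higher number from compound 1 to compound 2 (0.31 log units; beyond the scatter). Compound 3 `CC(C)c1ccc(/C=C2\Cc3cc(O)ccc3C2=O)cc1` differs from compound 2 by isopropyl in place of dimethylamino on an aromatic carbon. Going by the values given here, only the step from compound 1 to compound 2 bears on this change, and it concerns a different group, so it sets a scale rather than a direction. A modest step downward is therefore expected, a 1.5-fold lower number from compound 2 to compound 3 (0.19 log units; within the scatter), and compound 3 is estimated at 500 nM, within the range 200 nM to 1300 nM.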

Compound 3, half-maximal inhibitory concentration: 215 nM
Compound 3: middle estimate off by 2.3-fold (0.37 log units), on the high side, and the stated range covers the measured number.
By their numbers in this assay, from the lowest: compounds 3 and 1 (each within the scatter of the next); then compound 2.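

In this assay, swapping dimethylamino for isopropyl at this aromatic carbon gives a 3.6-fold lower number from compound 2 to compound 3 (0.55 log units; beyond the scatter), so two groups with the same number of heavy atoms do not read alike here. Replacing hydrogen with isopropyl gives a 1.7-fold lower number from compound 1 to compound 3 (0.24 log units; within the scatter), so this group, unlike dimethylamino, does not separate from hydrogen. No measurement shown explains the difference between these groups. Still open, going by these compounds, is how a methoxy group, a chlorine atom or a carboxylic acid would read at this position.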